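The compounds below may be only part of what the source reports. "The series", "measured", "known", "first", "only" and "open" are said of these compounds alone.

Working notes on the series. In a physicochemical assay for solubility, at pH 2 (a higher number here means a more soluble compound, a lower number a less soluble compound), compound 1 `CNc1nc(NCCN2CCNCC2)c2sc(-c3ccc(C(F)(F)F)cc3)cc2n1` gives 203 ug/mL and compound 2 `CN(C)CCCNc1nc(N(C)C)nc2cc(-c3ccc(C(F)(F)F)cc3)sc12` gives 212 ug/mL. Compound 2 therefore stands level with compound 1, within the scatter. Compound 3 `CN(C)CCCNc1nc(N2CCNCC2)nc2cc(-c3ccc(C(F)(F)F)cc3)sc12` differs from compound 2 in one place: piperazin-1-yl in place of dimethylamino on an aromatic carbon. Piperazin-1-yl takes the place of dimethylamino on an aromatic carbon, between two ring nitrogen atoms. No measured pair in the series differs in one place only, so the effect of this change in this assay has not been shown directly. The expectation rests on compound 2 at 212 ug/mL, and no step beyond the scatter is expected in either direction. The estimated change is small: a 1.0-fold higher number from compound 2 to compound 3 (0.02 log units; within the scatter). The expected value for compound 3 is 220 ug/mL, with an estimated range of 110 ug/mL to 420 ug/mL.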

Compound 3, solubility: 198 ug/mL
The estimate for compound 3 lay 1.1-fold (0.05 log units) above the measured number; measured number inside the range.
By their numbers in this assay, from the lowest: compounds 3, 1 and 2 (each within the scatter of the next).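

In this assay the series now has its first pair that differs in one place only (a 1.1-fold lower number from compound 2 to compound 3 (0.03 log units; within the scatter)). At this aromatic carbon, between two ring nitrogen atoms, the exchange of dimethylamino for piperazin-1-yl therefore leaves compound 2 and compound 3 level, although the entering group brings a six-membered non-aromatic ring and a hydrogen-bond donor. No measurement at hand bears on why the two stand level.

Going by these compounds, this rests on a single pair, so it remains open whether the same holds for other groups at this position, such as a morpholine ring, a carboxylic acid or a longer amine chain. Also open, on these data alone, is whether the exchange would read the same with a group other than the (3-(dimethylamino)propyl)amino group on the shared core.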